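The source may report more compounds than this note shows. Statements on the series, on what has been measured and on what is new or still open speak of the compounds shown alone.

Measured so far:
- compound 1, `Nc1scc(CN2CCN(c3ccccc3C(F)(F)F)CC2)c1C(=O)c1ccc(Cl)cc1`: -39%
- compound 2, `Nc1scc(CN2CCN(c3cccnc3)CC2)c1C(=O)c1ccc(Cl)cc1`: -2.7%

Both numbers come from a functional assay on CHO cells with adenosine receptor A1 (Homo sapiens) as the target, read by cAMP accumulation and immunoassay, with a stated time of 6 min, tested at 1 uM; on this read-out higher numbers stand for a weaker effect at the one concentration tested and lower numbers for a stronger effect. Among the compounds with values here, compound 2 stands highest of the two, that is, it shows the weaker effect; its only neighbour is compound 1, which lies well below it. Within the data shown here, the one step between them, a number 36.3 percentage points higher from compound 1 to compound 2 (beyond the scatter), was large and beyond the scatter: replacing 2-(trifluoromethyl)phenyl with pyridin-3-yl on the amine nitrogen in the ring cost most of the effect.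

Compound 3, `Nc1scc(CN2CCN(c3cccc4ccccc34)CC2)c1C(=O)c1ccc(Cl)cc1`, has not been measured. It differs from compound 2 in the same place: naphthalen-1-yl in place of pyridin-3-yl on an amine nitrogen in a ring. Among the measured compounds shown here, only the step from compound 1 to compound 2 bears on this change, and it points in the opposite direction: taking the pyridin-3-yl group out again and putting in a carbon-only aromatic group, here naphthalen-1-yl, resembles a partial return toward compound 1. Compound 3 is therefore expected to show a step of a number 22.3 percentage points lower from compound 2 to compound 3 (beyond the scatter) in this assay, downward, toward a stronger effect, though a two-ring group was not tried before and the size is uncertain. The estimate for compound 3 is -25%, with a range from -55% to 5%.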

Compound 3, a percentage reported as activity, at one concentration (the size of the read-out at that concentration, not a potency): 2.9%
The estimate for compound 3 lay 27.9 percentage points below the measured number; low and high end bracket the measured number.
By their numbers in this assay, from the lowest: compound 1; then compounds 2 and 3 (each within the scatter of the next).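

Naphthalen-1-yl, with two six-membered aromatic rings of carbon only, gives a number 5.6 percentage points higher from compound 2 to compound 3 (within the scatter) in this assay and so cannot be told apart from pyridin-3-yl, with its one ring holding a nitrogen, at this place on the amine nitrogen in the ring. The change from 2-(trifluoromethyl)phenyl gives a number 41.9 percentage points higher from compound 1 to compound 3 (beyond the scatter) and is large, so a carbon-only aromatic group at this place does not by itself bring back the stronger effect of compound 1, and among the three groups shown only 2-(trifluoromethyl)phenyl goes with that stronger effect. Nothing available explains why these groups differ in this way. 

The compounds shown leave open which part of 2-(trifluoromethyl)phenyl matters, since a plain phenyl group or a phenyl ring carrying a chlorine or a methoxy group would help separate the role of the trifluoromethyl group from that of the ring bearing it. On these data alone, each compound is also seen at only one concentration, so how potent any of them is remains open.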